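Shifting a Hydroxyl on the Third Aryl Arm

The compounds below may be only part of what the source reports. "The series", "measured", "known", "first", "only" and "open" are said of these compounds alone.

Of the compounds shown here, two have so far been measured in an ADME assay on HEK293 cells (Homo sapiens) for cytotoxicity, read by CCK-8 assay, with a stated time of 4 days; on this read-out lower numbers stand for stronger inhibition and higher numbers for weaker inhibition. Compound 1 `Oc1cccc(-c2cc(-c3cccc(O)c3)nc(-c3ccccc3O)c2)c1` gives > 50000 nM, which is a limit of the assay and not a number. Compound 2 `Oc1cccc(-c2cc(-c3ccccc3O)cc(-c3cccc(O)c3)n2)c1` gives 130 nM. For the measured compounds named here, compound 2 therefore holds the only actual number in this assay, the other entry being the limit at which one of the two values sits (the limit of > 50000 nM in this assay, at which 1 of the 2 values shown sits). Compound 3 `Oc1cccc(-c2cc(-c3ccccc3O)cc(-c3ccccc3O)n2)c1` has not yet been measured in this assay. It has the same atoms as compound 2, joined differently: 2-hydroxyphenyl in place of 3-hydroxyphenyl on an aromatic carbon. Going by the values given here, no measured pair differs in only this one place, so the size of this step cannot be read from any neighbouring step. In this assay the step from compound 2 to compound 3 is expected to run toward weaker inhibition, and to be larger than the usual scatter, since compound 1 gives > 50000 nM and shows that this series can lose measurable inhibition altogether. The estimate for compound 3 is 1500 nM, with a range from 200 nM to 50000 nM, the expected step being a 12-fold higher number from compound 2 to compound 3 (1.06 log units; beyond the scatter).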

Compound 3, half-maximal inhibitory concentration: 730 nM
For compound 3 the middle estimate is 2.1-fold (0.31 log units) above the measured one; measured number inside the range.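

In this assay, placing 2-hydroxyphenyl in place of 3-hydroxyphenyl on the aromatic carbon next to the ring nitrogen gives a 5.6-fold higher number from compound 2 to compound 3 (0.75 log units; beyond the scatter), so this position responds to where the hydroxyl sits on its arm, yet the change weakens inhibition without removing it. The same exchange of arms, set against the other isomer, gives an at least 68-fold lower number from compound 1 to compound 3 (1.83 log units; beyond the scatter), which shows that the place of the arms on the shared core can matter far more than this single hydroxyl shift. That larger step has only a bound on its size, for compound 1 stands at a limit of the assay and not a number: the limit of > 50000 nM in this assay, at which 1 of the 3 values shown sits.

What the values do not tell is why the hydroxyl's place changes the number, since they give no cause for either step. From the compounds shown here alone, it also stays open whether this arm would keep measurable inhibition with an amine or a methoxy group on the phenyl ring in place of the hydroxyl, or with a carboxylic acid there.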